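This account rests on a few compounds, and the source may have more. Where it says the series, first, only, none or still open, it means among the compounds named here.

Compound 1: `COc1ccc(-n2cc(NC(=O)c3ccc(NS(=O)(=O)c4ccccc4)cc3)cn2)cc1` — 47200 nM
Compound 2: `COc1cccc(-n2cc(NC(=O)c3ccc(NS(=O)(=O)c4ccccc4)cc3)cn2)c1` — 66200 nM

Both compounds were tested in a functional assay on HeLa cells (Homo sapiens) for inhibition, read by MTT assay, with a stated time of 48 h; a lower number here means a stronger inhibitor, a higher number a weaker inhibitor. Compound 1 and compound 2 sit within the scatter of each other, as the step of a 1.4-fold higher number from compound 1 to compound 2 (0.15 log units; within the scatter) shows. Compound 3 `COc1ccc(-n2cc(NC(=O)c3ccc(NS(=O)(=O)c4ccc(Cl)cc4)cc3)cn2)cc1` differs from compound 1 by chloro in place of hydrogen on an aromatic carbon. Among the compounds with values here, no measured step bears on this change; the only step available, a 1.4-fold higher number from compound 1 to compound 2 (0.15 log units; within the scatter), concerns a different part of the molecule and stays within the scatter. Compound 3 is therefore expected to show no shift beyond the scatter, giving an estimate of 42000 nM with a range of 15000 nM to 110000 nM, a step of a 1.1-fold lower number from compound 1 to compound 3 (0.05 log units; within the scatter).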

Compound 3, half-maximal inhibitory concentration: 25200 nM
The estimate for compound 3 lay 1.7-fold (0.22 log units) above the measured number; the range from low to high includes it.
By their numbers in this assay, from the lowest: compounds 3, 1 and 2 (each within the scatter of the next, the first and the last beyond it).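

In this assay the change from phenylsulfonyl to (4-chlorophenyl)sulfonyl gives a 1.9-fold lower number from compound 1 to compound 3 (0.27 log units; within the scatter) and so stays within the scatter. This is the first change shown at this end of the molecule, and it shows that a chloro can stand para to the large group without a shift beyond the scatter. As far as these compounds go, whether an amine, a carboxylic acid or a methoxy at the same position would shift the number beyond the scatter remains open. No measurement at hand speaks to what lies behind this result.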